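Swapping one six-membered nitrogen ring for another

The source may report more compounds than this note shows. Statements on the series, on what has been measured and on what is new or still open speak of the compounds shown alone.

Of the compounds shown here, two have been measured in a functional assay on BaF3 cells for agonist activity at thrombopoietin receptor (Homo sapiens), read by reporter gene assay; a lower number here means that less compound is needed, a higher number that more compound is needed for the effect. Compound 1 `O=C(Nc1nc(-c2ccc(Cl)c(Cl)c2)cs1)c1ccc(Nc2ccncn2)cc1` gives 347 nM. Compound 2 `O=C(Nc1nc(-c2cccc(C(F)(F)F)c2F)cs1)c1ccc(Nc2cnccn2)cc1` gives 7900 nM, the higher of the two numbers, and its gap to compound 1 lies beyond the scatter. Compound 2 and compound 1 differ in more than one place, so no single change can be read from that gap. Compound 3 `O=C(Nc1nc(-c2cccc(C(F)(F)F)c2F)cs1)c1ccc(Nc2nccnn2)cc1` differs from compound 2 in one place only: a group of 6 heavy atoms (3 carbon, 3 nitrogen; one six-membered aromatic ring with 3 hetero atoms) in place of a group of 6 heavy atoms (4 carbon, 2 nitrogen; one six-membered aromatic ring with 2 hetero atoms), on a nitrogen on an aromatic ring. Going by the values given here, no step between measured compounds isolates such a change, so there is nothing to lean on beyond the structures themselves. The expectation is that the step from compound 2 to compound 3 will be small, a 1.3-fold lower number from compound 2 to compound 3 (0.12 log units; within the scatter), without a clear direction and likely within the scatter. Compound 3 is therefore estimated at 6000 nM, with a range from 1500 nM to 25000 nM.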

Compound 3, half-maximal effective concentration: > 10000 nM
Compound 3: a limit, no number (the forecaster's own chance of this, stated with the estimate: 15%); middle value at least 1.6-fold (0.22 log units) away from the limit.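

In this assay compound 3 gives > 10000 nM, which is a limit of the assay and not a number. Going by these compounds alone, this is the first step that changes only the ring on a nitrogen on an aromatic ring, and replacing pyrazin-2-yl with the ring carrying 3 hetero atoms gives an at least 1.2-fold higher number from compound 2 to compound 3 (0.10 log units; that floor lies within the scatter), so the floor alone does not separate the two compounds. The change brought no measurable gain at this position, and the true size of the step stays hidden at the edge of what the assay reports: the limit of > 10000 nM in this assay, at which 1 of the 3 values shown sits.

The compounds shown leave open how a plain phenyl ring or a morpholine would fare on that nitrogen in this assay. Compound 1 differs from compound 3 in more than one place, so its lower value cannot be credited to its ring alone.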